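Swapping Phenyl for Sec-Butyl on the Shared Core

A few compounds are considered here, and "the series" means these few. Any claim that something is new, unique, unknown or untested is made for them only; others in the source may bear on it.

Compound 1 `CC(C)C(NC(=O)NO)C(=O)NC1CCCC1`: > 100000 nM
Compound 2 `O=C1NC(c2ccccc2)C(=O)N1Cc1ccccc1`: 78900 nM

In a functional assay on WI-38 cells (Homo sapiens) for inhibition (a lower number here means a stronger inhibitor, a higher number a weaker inhibitor), compound 1 sits at the limit of > 100000 nM in this assay, at which 1 of the 2 values shown sits, which is a limit of the assay rather than a number. Among the compounds with values here, compound 2 gives 78900 nM in this assay, the only number on record, and a weak one. Compound 3 `CCC(C)C1NC(=O)N(Cc2ccccc2)C1=O` differs from compound 2 by sec-butyl in place of phenyl on a saturated ring carbon. Within the data shown here, no step between measured compounds exists to show how such a change moves the number, so the expectation rests on compound 2 alone. Compound 3 is expected to stay weak, with a 1.5-fold higher number from compound 2 to compound 3 (0.18 log units; within the scatter) probably no larger than the scatter. Compound 3 is estimated at 120000 nM, between 30000 nM and 500000 nM.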

Compound 3, half-maximal inhibitory concentration: 74100 nM
For compound 3 the middle estimate is 1.6-fold (0.21 log units) above the measured one; low and high end bracket the measured number.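

Exchanging phenyl for sec-butyl on the saturated ring carbon gives a 1.1-fold lower number from compound 2 to compound 3 (0.03 log units; within the scatter) in this assay. At this position, then, an aromatic ring and an open carbon chain read the same, and the number stays weak with either group. No measurement shown here explains this similarity.

Going by these compounds, both groups contain carbon only, so it remains open whether an amine or a carboxylic acid at this position would move the number beyond the scatter. The effect of a much smaller group, such as methyl, is also unknown.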